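A few compounds are considered here, and "the series" means these few. Any claim that something is new, unique, unknown or untested is made for them only; others in the source may bear on it.

Measured in a functional assay, with a stated time of 10 min; on this read-out lower numbers stand for stronger inhibition and higher numbers for weaker inhibition:
compound 1, `CCOC(=O)c1cnn(-c2nc(-c3cccc(OC)c3OC)c(C#N)c(=O)n2C)c1N` — compound 1 gives 67 ug/mL
compound 2, `CCOC(=O)c1cnn(-c2nc(-c3ccccc3O)c(C#N)c(=O)n2C)c1N` — compound 2 gives 58 ug/mL
compound 3, `CCOC(=O)c1cnn(-c2nc(-c3ccccc3Cl)c(C#N)c(=O)n2C)c1N` — compound 3 gives 98 ug/mL

Compound 3 carries the highest of the three numbers, yet the steps of a 1.5-fold higher number from compound 1 to compound 3 (0.17 log units; within the scatter) and a 1.7-fold higher number from compound 2 to compound 3 (0.23 log units; within the scatter) both fall within the scatter, as does a 1.2-fold lower number from compound 1 to compound 2 (0.06 log units; within the scatter); on these data the three compounds cannot be told apart.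

Compound 4, `CCOC(=O)c1cnn(-c2nc(-c3cccc(O)c3O)c(C#N)c(=O)n2C)c1N`, has not been measured. It differs from compound 3 by 2,3-dihydroxyphenyl in place of 2-chlorophenyl on an aromatic carbon. The step that bears most directly on this change is a 1.7-fold higher number from compound 2 to compound 3 (0.23 log units; within the scatter), where hydroxy stands in place of chloro on an aromatic carbon; compound 1, with its 2,3-dimethoxyphenyl, also sits within the scatter of compound 2 and compound 3. For the measured compounds named here, since none of the measured steps leaves the scatter, no step beyond the scatter is expected here either. For compound 4 the expected step is a 1.5-fold lower number from compound 3 to compound 4 (0.18 log units; within the scatter), leaning toward the number of compound 2. Compound 4 is therefore estimated at 65 ug/mL, with a range of 35 ug/mL to 120 ug/mL, in this assay.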

Compound 4, half-maximal inhibitory concentration: 53 ug/mL
The estimate for compound 4 lay 1.2-fold (0.09 log units) above the measured number, within the range that was stated.
By their numbers in this assay, from the lowest: compounds 4, 2, 1 and 3 (each within the scatter of the next).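

In this assay this aromatic carbon, ortho to a cyano group, now carries a group with 2 hydrogen-bond donors in place of one with 0, and the read-out still cannot separate the two (a 1.8-fold lower number from compound 3 to compound 4 (0.27 log units; within the scatter)). Replacing both methoxy groups with hydroxy gives the same outcome (a 1.3-fold lower number from compound 1 to compound 4 (0.10 log units; within the scatter)), as does adding hydroxy in place of hydrogen on the phenyl ring (a 1.1-fold lower number from compound 2 to compound 4 (0.04 log units; within the scatter)), so all four aryl groups at this position read alike, and no measurement on hand accounts for this.

On these data alone, it remains open whether an amine or a carboxylic acid on this phenyl ring would give a step beyond the scatter. As far as these compounds go, the effect of a longer chain in place of the methyl group on the shared core is also open.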